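The compounds below may be only part of what the source reports. "The series", "measured", "known", "first", "only" and "open" are said of these compounds alone.

Measured compounds in a functional assay on HCT-15 cells (Homo sapiens) for inhibition, read by sulforhodamine B assay, with a stated time of 48 h; on this read-out lower numbers stand for stronger inhibition of growth and higher numbers for weaker inhibition of growth:
compound 1 `COc1cc(C)cc(-c2c(-c3ccnc(-c4ccc(C(C)=O)cc4)c3)cnn2CC#N)c1` gives 3140 nM
compound 2 `COc1cc(C)cc(-c2nn(CC#N)cc2-c2ccc(-c3cccc(C(C)=O)c3)nc2)c1` gives 2140 nM
compound 3 `Cc1cc(O)cc(-c2nn(CC#N)cc2-c2ccnc(-c3ccc(Oc4ccccc4)cc3)c2)c1` gives 2140 nM

Compound 3 sits level with compound 2 at the digits shown, and compound 1 lies within the usual scatter of both, so the three numbers do not separate. Going by the values given here, no step between measured compounds differs in a single place, so no measured step guides the next change.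

Compound 4 `Cc1cc(O)cc(-c2nn(CC#N)cc2-c2ccnc(-c3ccc(N(C)C)cc3)c2)c1` differs from compound 3 by dimethylamino in place of phenoxy on an aromatic carbon. Nothing in the measured set shows what this exchange does in this assay. With compound 3 at 2140 nM as the only anchor, the step is expected to be small, in no settled direction, and likely within the scatter. Compound 4 is estimated at 2500 nM, range 900 nM to 7000 nM, a step of a 1.2-fold higher number from compound 3 to compound 4 (0.07 log units; within the scatter) from compound 3 to compound 4.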

Compound 4, concentration for 50% growth inhibition: 3360 nM
Compound 4: middle estimate off by 1.3-fold (0.13 log units), on the low side, and the stated range covers the measured number.
By their numbers in this assay, from the lowest: compounds 2, 3, 1 and 4 (each within the scatter of the next).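

In this assay, dimethylamino in place of phenoxy on an aromatic carbon, para to a large group, gives a 1.6-fold higher number from compound 3 to compound 4 (0.20 log units; within the scatter). At this place, a group of 7 heavy atoms with a six-membered aromatic ring of carbon only and a group of 3 heavy atoms with no ring therefore do not separate on this read-out. Nothing measured here gives a cause for this result.

Open, on these data alone, is whether a primary amine or a carboxylic acid at this place would give a step beyond the scatter. Going by these compounds alone, with only one step available, no trend can be drawn for this place.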